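Swapping phenyl for neopentyl on compound 2

The compounds below may be only part of what the source reports. "The series", "measured", "known", "first", "only" and "open" are said of these compounds alone.

Compound 1 `O=C(NCc1cc(Cl)ccc1-n1cnnn1)[C@@H]1CC=NN1C(=O)[C@H](O)c1ccccc1F`: 1100 nM
Compound 2 `O=C([C@H](O)c1ccccc1)N1CC[C@@H]2C[C@@]21C(=O)NCc1cc(Cl)ccc1-n1cnnn1`: 1100 nM
Compound 3 `COC(C)(C)[C@@H](O)C(=O)N1C[C@H]2C[C@H]2[C@H]1C(=O)NCc1cc(Cl)ccc1-n1cnnn1`: 1000 nM

In a functional assay on a cell-free system (plasma, Homo sapiens), with a stated time of 3 min (on this read-out higher numbers stand for weaker inhibition and lower numbers for stronger inhibition), compound 2 gives 1100 nM, level with compound 1 and within the usual scatter of compound 3. Compound 4 `CC(C)(C)C[C@@H](O)C(=O)N1CC[C@@H]2C[C@@]21C(=O)NCc1cc(Cl)ccc1-n1cnnn1` differs from compound 2 by neopentyl in place of phenyl on a saturated chain carbon bound to a carbonyl carbon and an oxygen on a saturated carbon. Going by the values given here, no measured pair shows this change directly. Compound 3 also lacks phenyl on that carbon, though its core differs, and compound 3 gives 1000 nM. No shift beyond the scatter is therefore expected in this assay. The estimated 1.4-fold lower number from compound 2 to compound 4 (0.14 log units; within the scatter) is small. For compound 4 the estimated value is 800 nM, with an expected range from 250 nM to 2500 nM.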

Compound 4, half-maximal inhibitory concentration: 620 nM
Compound 4: the middle estimate sits 1.3-fold (0.11 log units) above what was measured, within the range that was stated.
By their numbers in this assay, from the lowest: compounds 4, 3, 1 and 2 (each within the scatter of the next).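

Compound 2 and compound 4 differ only at this saturated chain carbon, so in this assay the swap of phenyl for neopentyl can be read directly, as a 1.8-fold lower number from compound 2 to compound 4 (0.25 log units; within the scatter) with everything else held fixed. An aromatic ring at this place can therefore give way to an open chain without a change beyond the scatter. Nothing measured here bears on why the two groups give such similar numbers. Still open, going by these compounds, is whether an amine or a carboxylic acid on this carbon would move inhibition beyond the scatter. Also open, on these data alone, is whether neopentyl would behave the same way on the core of compound 1.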